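A Ring Saturation Step and Its Expected Clearance

This account rests on a few compounds, and the source may have more. Where it says the series, first, only, none or still open, it means among the compounds named here.

Compound 1 `O=C(CCSc1nc2ccccc2c(=O)[nH]1)N[C@H]1CC[C@H](c2nnc(-c3ccccc3)o2)CC1` was measured in an ADME assay (liver) for metabolic stability, with Liver microsome (Rattus norvegicus) as the target, using microsomes, with a stated time of 30 min, tested at 1 uM (a lower number here means slower removal, a higher number faster removal of the compound), where compound 1 gives 57 mL.min-1.g-1. Among the two compounds with numbers, compound 1 stands highest. Its nearest neighbour is compound 2 `O=C(CSc1nc2ccccc2c(=O)[nH]1)N[C@H]1CC[C@H](c2nnc(-c3ccccc3)o2)CC1`, which in this assay gives 20 mL.min-1.g-1, a gap that lies beyond the usual scatter. Among the compounds with values here, compound 2 differs from compound 1 in the length of the chain between the sulfur and the amide, so no step between measured compounds that changes a single place is available to guide a prediction.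

Compound 3 `O=C(CCSc1nc2c(c(=O)[nH]1)CCCC2)N[C@H]1CC[C@H](c2nnc(-c3ccccc3)o2)CC1` is yet to be measured. Compared with compound 1 it carries a group of 11 heavy atoms (8 carbon, 2 nitrogen, 1 oxygen; one six-membered non-aromatic ring of carbon only, one six-membered aromatic ring with 2 hetero atoms) in place of a group of 11 heavy atoms (8 carbon, 2 nitrogen, 1 oxygen; one six-membered aromatic ring of carbon only, one six-membered aromatic ring with 2 hetero atoms), on a sulfur; the rest of the molecule is kept as in compound 1. With compound 1 at 57 mL.min-1.g-1 as the only direct reference, the step from compound 1 to compound 3 is expected to be a 1.4-fold higher number from compound 1 to compound 3 (0.15 log units; within the scatter), a modest rise that could still fall within the scatter of repeated measurements. Compound 3 is therefore estimated at 80 mL.min-1.g-1, with a likely range from 35 mL.min-1.g-1 to 180 mL.min-1.g-1.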

Compound 3, intrinsic clearance in microsomes: 60 mL.min-1.g-1
Compound 3: middle estimate off by 1.3-fold (0.12 log units), on the high side; low and high end bracket the measured number.
By their numbers in this assay, from the lowest: compound 2; then compounds 1 and 3 (each within the scatter of the next).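

In this assay, the exchange on the sulfur gives a 1.1-fold higher number from compound 1 to compound 3 (0.02 log units; within the scatter), the first single-place step available in this set. At this position, where the other neighbour of the sulfur is a saturated chain carbon, compound 1 and compound 3 cannot be told apart, so replacing the six-membered aromatic ring of carbon only with a six-membered non-aromatic ring of carbon only leaves no readable difference in this read-out. Nothing measured here bears on why the two compounds read alike.

Going by these compounds, it remains open whether the same ring exchange would also leave no readable difference on the shorter chain of compound 2, whose number already lies beyond the scatter from that of compound 1. It is equally open how this read-out would respond to a fluorine, a hydroxyl, an amine or a carboxylic acid on the six-membered non-aromatic ring of carbon only, since the compounds shown carry none of these groups.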